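Extending the chain from compound 3 to compound 4

The source may report more compounds than this note shows. Statements on the series, on what has been measured and on what is new or still open speak of the compounds shown alone.

Compound 1 `CCCCOc1cc(OC)c(Br)cc1C(C)=O` gives 38200000 nM
Compound 2 `CCCCCCOc1cc(OC)c(Br)cc1C(C)=O` gives 34000000 nM
Compound 3 `CCCCCCCCOc1cc(OC)c(Br)cc1C(C)=O` gives 30900000 nM

These three values come from a functional assay, with stated times of 30 s and 6 min, in the presence of a further agent that is not named here (on this read-out lower numbers stand for stronger inhibition and higher numbers for weaker inhibition), and lie close together. Compound 3 stands within the scatter of both other compounds, as the two steps that reach it show (a 1.1-fold lower number from compound 2 to compound 3 (0.04 log units; within the scatter)) and (a 1.2-fold lower number from compound 1 to compound 3 (0.09 log units; within the scatter)).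

Compound 4 `CCCCCCCCCCOc1cc(OC)c(Br)cc1C(C)=O` has not yet been measured. It differs from compound 3 by ethyl in place of hydrogen on a saturated chain carbon, eight bonds along the chain from an oxygen on an aromatic ring.

The closest precedents are the same replacement made four bonds along the chain (a 1.1-fold lower number from compound 1 to compound 2 (0.05 log units; within the scatter)) and six bonds along it (a 1.1-fold lower number from compound 2 to compound 3 (0.04 log units; within the scatter)). The larger extension by butyl bears on it too (a 1.2-fold lower number from compound 1 to compound 3 (0.09 log units; within the scatter)). Going by these compounds, all three steps stay within the scatter, so no step beyond the scatter is expected in this assay for this further extension, and the direction of any small shift remains open. The estimated step is small (a 1.1-fold lower number from compound 3 to compound 4 (0.04 log units; within the scatter)). The estimated value for compound 4 is 28000000 nM (expected range 17000000 nM to 45000000 nM).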

Compound 4, half-maximal inhibitory concentration: 15000000 nM
Compound 4: middle estimate off by 1.9-fold (0.27 log units), on the high side; the whole stated range lies above it.
By their numbers in this assay, from the lowest: compound 4; then compounds 3, 2 and 1 (each within the scatter of the next).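

In this assay, going by these compounds alone, ethyl in place of hydrogen on a saturated chain carbon, eight bonds along the chain from an oxygen on an aromatic ring, gives a 2.1-fold lower number from compound 3 to compound 4 (0.31 log units; beyond the scatter), and the longer extensions give a 2.3-fold lower number from compound 2 to compound 4 (0.36 log units; beyond the scatter) and a 2.5-fold lower number from compound 1 to compound 4 (0.41 log units; beyond the scatter), so that this chain length sets one compound apart from all three others, which the earlier compounds, all within the scatter of one another, did not show. This does not establish that the ethyl change has a larger effect at eight bonds than at four, as the two steps are not separated from each other: the same change on two cores in this assay, a 1.1-fold lower number (0.05 log units; within the scatter) from compound 1 to compound 2 and a 2.1-fold lower number (0.31 log units; beyond the scatter) from compound 3 to compound 4, 1.8-fold (0.26 log units) apart, within the scatter of two such steps. The longer butyl change likewise gives no firm difference between the two places where it is made: the same change on two cores in this assay, a 1.2-fold lower number (0.09 log units; within the scatter) from compound 1 to compound 3 and a 2.3-fold lower number (0.36 log units; beyond the scatter) from compound 2 to compound 4, 1.8-fold (0.26 log units) apart, within the scatter of two such steps.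

Within the data shown here, whether a longer chain than the one in compound 4 would lower the number further, or whether the trend would level off or turn, stays open. Also open, going by these compounds, is how a branched chain, or a chain ending in an amine or a carboxylic acid, would compare at this position on the shared core.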